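The source may hold more compounds than are shown below. What is called first, only, known or untested is meant among the compounds shown, and "the series" means these compounds.

In a functional assay on THP-1 cells (Homo sapiens) for inhibition, read by sulforhodamine B assay, with a stated time of 48 h, tested at 50 uM (on this read-out higher numbers stand for more inhibition of growth at the one concentration tested and lower numbers for less inhibition of growth), compound 1 `O=C1C(=O)N(CCCCn2cc(COc3cc(=O)oc4ccccc34)nn2)c2ccc([N+](=O)[O-])cc21` gives 55% and compound 2 `O=C1C(=O)N(CCCCCn2cc(COc3cc(=O)oc4ccccc34)nn2)c2ccc(Cl)cc21` gives 59%. These two values lie within the usual scatter of each other, so compound 2 stands level with compound 1. Compound 3 `COc1ccc2c(c1)C(=O)C(=O)N2CCCCCn1cc(COc2cc(=O)oc3ccccc23)nn1` differs from compound 2 in a single place, with methoxy in place of chloro on an aromatic carbon. Going by the values given here, no measured pair shows this swap, so the data offer no direct guide. The expected step in this assay, a number 4 percentage points lower from compound 2 to compound 3 (within the scatter), is estimated to stay within the scatter. For compound 3 the estimated value is 55%, with an expected range of 42% to 68%.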

Compound 3, percent growth inhibition at one concentration: 30%
The estimate for compound 3 lay 25 percentage points above the measured number, and the stated range ends above it.
By their numbers in this assay, from the lowest: compound 3; then compounds 1 and 2 (each within the scatter of the next).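

Going by these compounds alone, this is the first sign that the group on this aromatic carbon matters in this assay: methoxy in place of chloro gives a number 29 percentage points lower from compound 2 to compound 3 (beyond the scatter), although the swap adds only one heavy atom and one hydrogen-bond acceptor. Compound 1 and compound 2 differ in more than one place, so they could not show this. Nothing measured here explains the loss.

Still open, going by these compounds, is whether chloro is needed here, or whether fluoro, methyl or an amine on this carbon would match compound 2. Also open, on these data alone, is whether this swap would have the same effect with a longer chain.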